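A few compounds are considered here, and "the series" means these few. Any claim that something is new, unique, unknown or untested is made for them only; others in the source may bear on it.

Compound 1 `CCN(CC)c1ccc2cc(C(=O)c3ccc(N4CCN(C(=O)CN5CCNCC5)CC4)cc3)oc2c1`: 1220 nM; compound 2 `CCN(CC)c1ccc2cc(C(=O)c3ccc(N4CCN(C(=O)CN5CCN(S(=O)(=O)c6ccc(C#N)cc6)CC5)CC4)cc3)oc2c1`: > 40000 nM.

In a functional assay on SGC-7901 cells (Homo sapiens) for cytotoxicity, read by MTT assay, with a stated time of 48 h (a higher number here means a weaker inhibitor, a lower number a stronger inhibitor), compound 1 gives 1220 nM. For compound 2 the value > 40000 nM is a limit of the assay and not a number. Compound 2 thus stands at the limit of > 40000 nM in this assay, at which 1 of the 2 values shown sits. For the measured compounds named here, the only measured step, an at least 32-fold higher number from compound 1 to compound 2 (1.51 log units; beyond the scatter), bears on the change to compound 3 `CCN(CC)c1ccc2cc(C(=O)c3ccc(N4CCN(C(=O)CN5CCN(Cc6ccc(F)c(F)c6)CC5)CC4)cc3)oc2c1`, which is 3,4-difluorobenzyl in place of (4-cyanophenyl)sulfonyl on an amine nitrogen in a ring: the (4-cyanophenyl)sulfonyl leaves, and a 3,4-difluorobenzyl enters where compound 1 carried hydrogen. A large downward step is expected, though not fully back to the level of compound 1. Compound 3 is expected at 3500 nM (range 800 nM to 15000 nM), an estimated step of an at least 11-fold lower number from compound 2 to compound 3 (1.05 log units; beyond the scatter).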

Compound 3, half-maximal inhibitory concentration: 1780 nM
For compound 3 the middle estimate is 2.0-fold (0.29 log units) above the measured one; the range from low to high includes it.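

Placing a ring-bearing group on this amine nitrogen in a ring does not by itself abolish activity in this assay: replacing (4-cyanophenyl)sulfonyl with 3,4-difluorobenzyl gives a large step (an at least 22-fold lower number from compound 2 to compound 3 (1.35 log units; beyond the scatter)), while replacing hydrogen with 3,4-difluorobenzyl gives a step within the scatter (a 1.5-fold higher number from compound 1 to compound 3 (0.16 log units; within the scatter)). The loss in compound 2 therefore goes with the (4-cyanophenyl)sulfonyl, not with every ring-bearing group here. The value of compound 2 is a limit of the assay: (the limit of > 40000 nM in this assay, at which 1 of the 3 values shown sits). From the compounds shown here alone, whether a plain benzyl, a methyl or an unsubstituted phenylsulfonyl would read like compound 3 or compound 2 stays open.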